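The compounds below may be only part of what the source reports. "The series", "measured", "known", "first", "only" and "open" are said of these compounds alone.

Measured compounds:
Compound 1, `Cc1cc(C)cc(/C=C(\C(=O)c2ccc(Cl)cc2)S(=O)(=O)c2ccc(Br)cc2)c1`, gives 10000 nM.
Compound 2, `COc1ccc(/C=C(\C(=O)c2ccc(Cl)cc2)S(=O)(=O)Cc2ccccc2Cl)cc1`, gives 50000 nM.
Compound 3, `CCOc1ccc(/C=C(\C(=O)c2ccc(Cl)cc2)S(=O)(=O)Cc2ccccc2Cl)cc1OC`, gives 10000 nM.

These three compounds were tested in a functional assay on DU-145 cells (Homo sapiens) for inhibition, read by trypan blue exclusion, with a stated time of 96 h; a lower number here means a stronger inhibitor of growth, a higher number a weaker inhibitor of growth. Compound 2 stands with the highest number of the three, so it is the weakest inhibitor of growth among them; compound 1 and compound 3 each sit at a lower number by the same margin, one that is beyond the usual scatter.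

The compound still to be measured is compound 4, `COc1ccc(/C=C(\C(=O)c2ccc(Cl)cc2)S(=O)(=O)c2ccc(Br)cc2)cc1`. Compared with compound 2 it carries one change: 4-bromophenyl in place of 2-chlorobenzyl on a sulfonyl sulfur.

Among the compounds with values here, only one step between measured compounds is available, a 5.0-fold lower number from compound 2 to compound 3 (0.70 log units; beyond the scatter), and it alters the group on the chain carbon rather than the group on the sulfonyl sulfur, so it does not speak directly to the change made here. Compound 1 carries the same 4-bromophenyl on its sulfonyl sulfur and gives 10000 nM, but it also differs from compound 2 elsewhere, so its value can only hint that this sulfonyl group is compatible with a lower number. The expectation is therefore a modest move toward a lower number in this assay, with real uncertainty.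

Compound 4 is expected to show a step of a 2.5-fold lower number from compound 2 to compound 4 (0.40 log units; beyond the scatter).

Compound 4 is estimated at 20000 nM, within a range from 5000 nM to 60000 nM.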

Compound 4, concentration for 50% growth inhibition: 10000 nM
The estimate for compound 4 lay 2.0-fold (0.30 log units) above the measured number, within the range that was stated.
By their numbers in this assay, from the lowest: compounds 1, 3 and 4 (each within the scatter of the next); then compound 2.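

In this assay, putting 4-bromophenyl in place of 2-chlorobenzyl on the sulfonyl sulfur, with the rest of compound 2 kept, gives a 5.0-fold lower number from compound 2 to compound 4 (0.70 log units; beyond the scatter). Within the data shown here, this is the first direct reading of this position, since compound 1 carries the same 4-bromophenyl but also differs from compound 2 in a second place, so it could offer only a hint. With 4-bromophenyl held on the sulfur, changing 3,5-dimethylphenyl to 4-methoxyphenyl on the double-bonded chain carbon shows no change at the digits printed from compound 1 to compound 4 (within the scatter), so this assay does not separate these two groups in this setting.

The change on the sulfur swaps chlorine for bromine and benzyl for phenyl in one step, so the compounds shown cannot say which part goes with the lower number; a 4-chlorophenyl or a 4-bromobenzyl on the sulfonyl sulfur would pull the two apart. From the compounds shown here alone, no measurement among those available explains why this swap lowers the number, and how a group such as an amine would fare at this position also remains open.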